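The compounds below may be only part of what the source reports. "The series", "measured", "known", "first", "only" and "open" are said of these compounds alone.

Compound 1 `CC(=O)Nc1cc(-c2ccc(OC[C@@H](N)CC(C)C)c(C)c2)ccn1`: 1.1 nM; compound 2 `COC(=O)Nc1cc(-c2ccc(OC[C@@](C)(N)CC(C)C)c(Cl)n2)ccn1`: 1.2 nM; compound 3 `CC(=O)Nc1cc(-c2cc(F)c(OC[C@@H](N)CC(C)C)cc2F)ccn1`: 6.7 nM.

In an assay on HEK293F cells for inhibition of AP2-associated protein kinase 1 (Homo sapiens), read by Western blot, with a stated time of 3 h (a lower number here means a stronger inhibitor, a higher number a weaker inhibitor), compound 1 gives the lowest of the three numbers. Compound 2 lies within the scatter of it, while compound 3 gives a number beyond the scatter above it. Compound 4 `CC(=O)Nc1cc(-c2ccc(OC[C@@H](N)CC(C)C)c(OC(F)(F)F)c2)ccn1` differs from compound 1 in one place: trifluoromethoxy in place of methyl on an aromatic carbon, on the aromatic carbon ortho to the (2-amino-4-methylpentyl)oxy group. Among the measured compounds shown here, no measured pair shows this change, so its size is open. For the measured compounds named here, since compound 1 already stands at the low end with 1.1 nM, and the entering group has no precedent among the measured compounds, a small rise in the number is expected, near the edge of the scatter. Compound 4 is estimated at 2.5 nM, within 0.8 nM to 8 nM. The expected step is a 2.3-fold higher number from compound 1 to compound 4 (0.36 log units; beyond the scatter).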

Compound 4, half-maximal inhibitory concentration: 0.45 nM
Beside the measured number, compound 4's estimate is 5.6-fold (0.74 log units) above it, outside the stated range (below it).
By their numbers in this assay, from the lowest: compound 4; then compounds 1 and 2 (each within the scatter of the next); then compound 3.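

In this assay, the aromatic carbon ortho to the (2-amino-4-methylpentyl)oxy group carries trifluoromethoxy in place of methyl with a 2.4-fold lower number from compound 1 to compound 4 (0.39 log units; beyond the scatter), a modest step. Among the compounds shown here, the number at this position can thus still fall from the already low value of compound 1, and the earlier compounds held no change at this carbon that could be read alone. Nothing at hand bears on the reason for this step. As far as these compounds go, what methoxy or trifluoromethyl would give at this same carbon stays open, so the step cannot yet be assigned to any one part of the entering group.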